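The source may hold more compounds than are shown below. What is called first, only, known or untested is meant among the compounds shown, and "the series" means these compounds.

In a functional assay on CAL-27 cells (Homo sapiens) for cytotoxicity, read by MTT assay, with a stated time of 72 h (a higher number here means a weaker inhibitor, a lower number a stronger inhibitor), compound 2 `CN(C)c1ccc(C(=O)N(CCCCCC(=O)NO)CC(=O)NC2CCCCC2)cc1` gives 2970 nM, within the scatter of compound 1 `O=C(CCCCCN(CC(=O)NC1CCCCC1)C(=O)c1cccc2ccccc12)NO` at 2400 nM, so the two values do not separate. Compound 3 `Cc1cc(C)cc(C(=O)N(CCCCCC(=O)NO)CC(=O)NC2CCCCC2)c1` carries 3,5-dimethylphenyl in place of 4-(dimethylamino)phenyl on a carbonyl carbon. Going by the values given here, only one measured step bears on this place, a 1.2-fold higher number from compound 1 to compound 2 (0.09 log units; within the scatter), with 4-(dimethylamino)phenyl in place of naphthalen-1-yl. That step stayed within the scatter, although the two groups differ. Among the compounds with values here, no measured compound yet carries 3,5-dimethylphenyl, and a single step is thin evidence. On that basis, no step beyond the scatter is expected in this assay. The estimate amounts to a 1.1-fold lower number from compound 2 to compound 3 (0.06 log units; within the scatter), with no real change in either direction expected. For compound 3 the expected value is 2600 nM, with an estimated range of 1200 nM to 5500 nM.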

Compound 3, half-maximal inhibitory concentration: 1130 nM
Estimate against measurement, compound 3: 2.3-fold (0.36 log units) above; measured number below the stated range.
By their numbers in this assay, from the lowest: compound 3; then compounds 1 and 2 (each within the scatter of the next).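

This position does respond in this assay, which the earlier pair did not show: the change to 3,5-dimethylphenyl gives a 2.6-fold lower number from compound 2 to compound 3 (0.42 log units; beyond the scatter) and a 2.1-fold lower number from compound 1 to compound 3 (0.33 log units; beyond the scatter) as two modest steps. The same entering group separates compound 3 from both the 4-(dimethylamino)phenyl of compound 2 and the naphthalen-1-yl of compound 1, making compound 3 the strongest of the three here, while compounds 1 and 2 remain within the scatter of each other. Nothing measured here accounts for this difference.

Going by these compounds, whether the step depends on both methyl groups remains open, and a 3-methylphenyl, 3,5-dichlorophenyl or pyridin-3-yl group on this carbonyl would bear on that. On these data alone, the effect of a longer chain, or of a benzyl amide in place of the cyclohexyl amide, alongside 3,5-dimethylphenyl is also open.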